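A few compounds are considered here, and "the series" means these few. Any claim that something is new, unique, unknown or untested is made for them only; others in the source may bear on it.

Measured so far in an ADME assay on Jurkat cells (Homo sapiens) for cytotoxicity, read by MTT assay; on this read-out higher numbers stand for weaker inhibition and lower numbers for stronger inhibition:
Compound 1 `O/N=C(\COc1cccc2ccccc12)c1ccccc1`: > 50000 nM
Compound 2 `O/N=C(\COc1cccc2ccccc12)c1ccc(Cl)cc1`: > 50000 nM

Compound 1 has no exact number, only a limit of > 50000 nM. Compound 2 likewise has only a limit, > 50000 nM.

Compound 3 `COc1ccc(/C(COc2cccc3ccccc23)=N/O)cc1` differs from compound 1 by methoxy in place of hydrogen on an aromatic carbon, with methoxy in place of hydrogen on an aromatic carbon. Within the data shown here, the one measured step that bears on this also replaces hydrogen on an aromatic carbon, here with chloro: a step that the two limits leave unreadable from compound 1 to compound 2. On these data alone, its size is unknown, and the evidence is the limit of > 50000 nM in this assay, at which 2 of the 2 values shown sit. In this assay, no clear shift in either direction is therefore expected: a step that the limit leaves unreadable from compound 1 to compound 3. The estimate for compound 3 is 60000 nM, with an expected range of 25000 nM to 150000 nM.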

Compound 3, half-maximal inhibitory concentration: 31800 nM
Estimate against measurement, compound 3: 1.9-fold (0.28 log units) above; measured number inside the range.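

With methoxy on the aromatic carbon para to a large group, compound 3 gives the only exact number shown in this assay, so a change at this position can now be sized, if only as a floor: an at least 1.5-fold lower number from compound 1 to compound 3 (0.19 log units; that floor lies within the scatter). Against chloro at the same place, the reading is an at least 1.5-fold lower number from compound 2 to compound 3 (0.19 log units; that floor lies within the scatter). Both floors rest on limits, so the true size of each step stays unfixed: the limit of > 50000 nM in this assay, at which 2 of the 3 values shown sit.

The compounds shown leave open whether a longer chain such as ethoxy would also give an exact number in this assay. The same question stands for an amine or a carboxylic acid at this position.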